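This account rests on a few compounds, and the source may have more. Where it says the series, first, only, none or still open, it means among the compounds named here.

Compound 1 `CN(C(=O)c1cc(-c2ccccc2Cl)on1)[C@H]1CN(S(=O)(=O)c2ccccc2)C[C@@H]1C(=O)N[C@H]1CCCNC1`: 13 mL.min-1.g-1
Compound 2 `CN(C(=O)[C@H]1CN(S(=O)(=O)c2ccccc2)C[C@@H]1NC(=O)c1cc(-c2ccccc2Cl)on1)[C@H]1CCCNC1`: 4.2 mL.min-1.g-1

In an ADME assay on microsomes from liver (Homo sapiens) for metabolic stability (on this read-out lower numbers stand for slow clearance and higher numbers for fast clearance), compound 2 gives 4.2 mL.min-1.g-1, the lower of the two numbers, and the gap up to compound 1 lies beyond the scatter. Compound 3 `CN(C(=O)[C@H]1CN(S(=O)(=O)c2ccccc2)C[C@@H]1N(C)C(=O)c1cc(-c2ccccc2Cl)on1)[C@H]1CCCNC1` has methyl in place of hydrogen on an amide-type nitrogen of compound 2 (methyl in place of hydrogen on an amide-type nitrogen). Within the data shown here, no measured pair isolates this change, so the basis is thin. Among the measured compounds shown here, compound 1, at 13 mL.min-1.g-1, is the only guide to direction. A modest rise in this assay is expected, a 1.9-fold higher number from compound 2 to compound 3 (0.28 log units; within the scatter). Compound 3 is estimated at 8 mL.min-1.g-1, with an expected range of 3.5 mL.min-1.g-1 to 20 mL.min-1.g-1.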

Compound 3, intrinsic clearance in microsomes: 20 mL.min-1.g-1
For compound 3 the middle estimate is 2.5-fold (0.40 log units) below the measured one; measured number inside the range.
By their numbers in this assay, from the lowest: compound 2; then compounds 1 and 3 (each within the scatter of the next).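

In this assay, among these compounds, methyl in place of hydrogen on the amide-type nitrogen gives a 4.8-fold higher number from compound 2 to compound 3 (0.68 log units; beyond the scatter) as the first single-place change, and this step lies beyond the scatter. The second step, a 1.5-fold higher number from compound 1 to compound 3 (0.19 log units; within the scatter) for the same kind of change, stays within the scatter and leaves these two compounds unseparated. Nothing shown accounts for the rise from compound 2.

Going by these compounds, it remains open whether ethyl or a longer chain on this nitrogen would follow methyl. Also open, on these data alone, is whether the step from compound 2 would hold with an amine or a carboxylic acid elsewhere on the shared core.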